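The source may hold more compounds than are shown below. What is called first, only, known or untested is meant among the compounds shown, and "the series" means these compounds.

The measured compounds are: compound 1, `O=C(Nc1ccc(Oc2ccnc3[nH]ccc23)cc1)c1cn(-c2ccccc2)c2ccccc2c1=O`, with 2250 nM; compound 2, `O=C(Nc1ccc(Oc2ccnc3[nH]ccc23)cc1)c1cn(-c2ccc(F)cc2)c2ccccc2c1=O`, with 450 nM; and compound 3, `Cn1ccc2c(Oc3ccc(NC(=O)c4cn(-c5ccccc5)c5ccccc5c4=O)cc3F)ccnc21`, with 2170 nM.

All three were tested in a functional assay on HepG2 cells (Homo sapiens) for inhibition, read by MTT assay, with a stated time of 72 h; a lower number here means a stronger inhibitor, a higher number a weaker inhibitor. Compound 1 and compound 2 share a core and differ in one place: fluoro in place of hydrogen on an aromatic carbon. That single change gave a 5.0-fold lower number from compound 1 to compound 2 (0.70 log units; beyond the scatter). Compound 3 carries a different core from compound 1; how the two cores differ is not broken down here. In this assay compound 3 gives 2170 nM, and that number lies within the scatter of the value of compound 1, so the two cannot be ordered.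

Compound 4, `Cn1ccc2c(Oc3ccc(NC(=O)c4cn(-c5ccc(F)cc5)c5ccccc5c4=O)cc3F)ccnc21`, has not yet been measured. It differs from compound 3 in exactly the way compound 2 differs from compound 1: fluoro in place of hydrogen on an aromatic carbon. The place is described in the same words for both pairs, so the change is the same. Only one measured example of this change exists among these compounds, and the two cores are not the same, so the outcome for compound 4 rests on a single precedent. Given the step from compound 1 to compound 2 in this assay, a 5.0-fold lower number from compound 1 to compound 2 (0.70 log units; beyond the scatter), a step of similar direction and somewhat smaller size is expected, a 3.9-fold lower number from compound 3 to compound 4 (0.60 log units; beyond the scatter), from compound 3 to compound 4. Compound 4 is therefore expected to give about 550 nM in this assay, most likely between 200 nM and 1600 nM.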

Compound 4, half-maximal inhibitory concentration: 2010 nM
The estimate for compound 4 lay 3.7-fold (0.56 log units) below the measured number; the measured number lies above the stated range.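

In this assay, the change from phenyl to 4-fluorophenyl did not carry over from one core to the other with the same result: the same change on two cores in this assay, a 5.0-fold lower number (0.70 log units; beyond the scatter) from compound 1 to compound 2 and a 1.1-fold lower number (0.03 log units; within the scatter) from compound 3 to compound 4, 4.6-fold (0.67 log units) apart, beyond the scatter of two such steps. For the compounds shown here, on the core of compound 3, the new step is a 1.1-fold lower number from compound 3 to compound 4 (0.03 log units; within the scatter), so the two compounds on that core cannot be ordered, and the clear gain in compound 2 over compound 1 has no counterpart there. Going by these compounds alone, with only one pair on each core, this shows that a step measured on one core of this series cannot simply be assumed on the other, but it does not show which difference between the cores sets the two steps apart, nor how the change would behave on any further core.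

The compounds shown leave open whether chloro, methoxy or an amine in place of the fluoro would give a step on either core, and whether such a step would again differ between them. They also leave open how phenyl to 4-fluorophenyl would read on a core carrying a further group, such as a carboxylic acid or a longer chain.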